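This account rests on a few compounds, and the source may have more. Where it says the series, first, only, none or still open, it means among the compounds named here.

Three measured compounds share one core. Compound 2 `Cc1cc(C)c(S(C)(=O)=O)cc1C(=O)N=C(N)N` gives 11 nM in a functional assay for inhibition of sodium/hydrogen exchanger (Oryctolagus cuniculus) (on this read-out lower numbers stand for stronger inhibition and higher numbers for weaker inhibition), the lowest of the three numbers shown, though that standing against compound 1 rests on a step within the scatter. Compound 1 `Cc1cc(Br)c(S(C)(=O)=O)cc1C(=O)N=C(N)N` gives 12 nM in this assay, and the step of a 1.1-fold lower number from compound 1 to compound 2 (0.04 log units; within the scatter) tells nothing beyond the scatter. Compound 3 `Cc1cc(Sc2cccc(Cl)c2)c(S(C)(=O)=O)cc1C(=O)N=C(N)N` gives 37 nM in this assay; here both a 3.1-fold higher number from compound 1 to compound 3 (0.49 log units; beyond the scatter) and a 3.4-fold higher number from compound 2 to compound 3 (0.53 log units; beyond the scatter) lie beyond the scatter.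

Compound 4 `Cc1cc(Sc2ccccc2)c(S(C)(=O)=O)cc1C(=O)N=C(N)N` is not yet measured. Relative to compound 2 the change is phenylsulfanyl in place of methyl on an aromatic carbon. For the measured compounds named here, the steps that bear on it are a 3.4-fold higher number from compound 2 to compound 3 (0.53 log units; beyond the scatter) and a 3.1-fold higher number from compound 1 to compound 3 (0.49 log units; beyond the scatter), both modest and in the same direction, with (3-chlorophenyl)sulfanyl entering where phenylsulfanyl enters here. For compound 4 a step of the same kind, perhaps somewhat smaller, is expected, a 2.7-fold higher number from compound 2 to compound 4 (0.44 log units; beyond the scatter). For compound 4 the estimated value in this assay is 30 nM, with a range from 14 nM to 65 nM.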

Compound 4, half-maximal inhibitory concentration: 14 nM
Estimate against measurement, compound 4: 2.1-fold (0.33 log units) above; low and high end bracket the measured number.
By their numbers in this assay, from the lowest: compounds 2, 1 and 4 (each within the scatter of the next); then compound 3.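

At this position, ortho to a methylsulfonyl group, this assay does not separate phenylsulfanyl from methyl or bromo: the steps of a 1.3-fold higher number from compound 2 to compound 4 (0.10 log units; within the scatter) and a 1.2-fold higher number from compound 1 to compound 4 (0.07 log units; within the scatter) both stay within the scatter, so the much larger group is accommodated here without a readable change. The modest rise seen earlier with compound 3 therefore goes with the chloro and not with the phenylsulfanyl group as such, since the step of a 2.6-fold lower number from compound 3 to compound 4 (0.42 log units; beyond the scatter) lies beyond the scatter. No measurement shown here speaks to why the chloro carries this difference.

On these data alone, whether a chloro elsewhere on that ring, or an amine or a carboxylic acid in its place, moves the number in the same way remains open. Also open, as far as these compounds go, is whether phenoxy or benzyl in place of phenylsulfanyl stays within the scatter of compound 2.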